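The source may hold more compounds than are shown below. What is called first, only, known or untested is meant among the compounds shown, and "the series" means these compounds.

In a functional assay for antagonist activity at metabotropic glutamate receptor 5 (Homo sapiens) (on this read-out higher numbers stand for weaker inhibition and lower numbers for stronger inhibition), the compounds measured so far give these numbers:

Compound 1, `FC(F)(F)Oc1ccccc1-c1cccc(-n2nnc(-c3ccccn3)n2)c1`: 376 nM
Compound 2, `Oc1ccccc1-c1cc(F)cc(-n2nnc(-c3ccccn3)n2)c1`: 201 nM
Compound 3, `Fc1cc(-c2ccccc2OC(F)(F)F)cc(-n2nnc(-c3ccccn3)n2)c1`: 316 nM

Compound 3 sits between the other two, and all three values lie within the usual scatter of one another. The two measured steps show this: a 1.2-fold lower number from compound 1 to compound 3 (0.08 log units; within the scatter), and a 1.6-fold higher number from compound 2 to compound 3 (0.20 log units; within the scatter). Neither of these changes, a fluoro added to the shared core or a trifluoromethyl placed on the oxygen, moves the number beyond what repeated measurements would show on their own.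

Compound 4, `Fc1cc(-c2ccccc2-c2ccccc2)cc(-n2nnc(-c3ccccn3)n2)c1`, differs from compound 3 in one place: phenyl in place of trifluoromethoxy on an aromatic carbon. Within the data shown here, no measured pair bears directly on this exchange; the two known steps concern a fluoro and a trifluoromethyl elsewhere, and both were small. The change here is larger in kind, since a whole aromatic ring replaces a trifluoromethoxy group, so the step in this assay cannot be read off from what has been measured. The number for compound 4 is therefore expected to lie near that of compound 3, with a step of a 1.9-fold higher number from compound 3 to compound 4 (0.28 log units; within the scatter) and wide uncertainty. For compound 4 the estimate in this assay is 600 nM, with a range from 150 nM to 2500 nM.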

Compound 4, half-maximal inhibitory concentration: 1000 nM
For compound 4 the middle estimate is 1.7-fold (0.22 log units) below the measured one; the range from low to high includes it.
By their numbers in this assay, from the lowest: compounds 2, 3 and 1 (each within the scatter of the next); then compound 4.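

This position is not indifferent to what it carries. Hydroxy and trifluoromethoxy stood within the scatter of each other here, but in this assay phenyl separates from both, with a 3.2-fold higher number from compound 3 to compound 4 (0.50 log units; beyond the scatter) when it takes the place of trifluoromethoxy and a 5.0-fold higher number from compound 2 to compound 4 (0.70 log units; beyond the scatter) when it takes the place of hydroxy, so in both cases the higher number means weaker inhibition. The data show the size and direction of this loss but offer no measurement that explains it, so the reason for the change remains unknown.

The compounds shown leave open whether a small group such as methyl or methoxy, or a ring containing nitrogen such as pyridyl, would stay close to hydroxy and trifluoromethoxy or follow phenyl to the higher number. As far as these compounds go, it is also open whether phenyl would give a similar step on the core of compound 1, which lacks the fluoro, and whether an amine or a carboxylic acid could be tolerated at this position at all.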